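The source may report more compounds than this note shows. Statements on the series, on what has been measured and on what is new or still open speak of the compounds shown alone.

Compound 2 `CCOC(=O)C1=Cc2ccccc2OC1(OCc1cn(-c2ccc(F)c([N+](=O)[O-])c2)nn1)C(F)(F)F` gives the highest of the two numbers in a functional assay on MCF7 cells (Homo sapiens) for inhibition, read by MTT assay, with a stated time of 24 h (a lower number here means a stronger inhibitor, a higher number a weaker inhibitor), with 16200 nM. Compound 1 `CCOC(=O)C1=Cc2ccccc2OC1(OCc1cn(CC(=O)NC2CCCCC2)nn1)C(F)(F)F` is its nearest neighbour, and in this assay compound 1 gives 12100 nM. For the measured compounds named here, the one step so far, a 1.3-fold higher number from compound 1 to compound 2 (0.13 log units; within the scatter), is a change on the aromatic nitrogen of the core. Compound 3 `CCOC(=O)C1=Cc2ccccc2OC1(OCc1cn(CC(=O)Nc2ccccc2F)nn1)C(F)(F)F` differs from compound 2 by ((2-fluorophenyl)carbamoyl)methyl in place of 4-fluoro-3-nitrophenyl on an aromatic nitrogen. Going by the values given here, since the single comparable step stays within the scatter, no step beyond the scatter is expected for a 1.2-fold lower number from compound 2 to compound 3 (0.10 log units; within the scatter). Compound 3 is therefore estimated at 13000 nM, with a range from 5000 nM to 35000 nM.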

Compound 3, half-maximal inhibitory concentration: 42100 nM
For compound 3 the middle estimate is 3.2-fold (0.51 log units) below the measured one; measured number above the stated range.
By their numbers in this assay, from the lowest: compounds 1 and 2 (each within the scatter of the next); then compound 3.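

For the compounds shown here, at the aromatic nitrogen, the group can matter in this assay (a 2.6-fold higher number from compound 2 to compound 3 (0.41 log units; beyond the scatter)), the first step here beyond the scatter. The amide-type nitrogen is also sensitive, as 2-fluorophenyl in place of cyclohexyl gives a step of similar kind (a 3.5-fold higher number from compound 1 to compound 3 (0.54 log units; beyond the scatter)). No evidence at hand bears on why these steps occur. From the compounds shown here alone, it remains open whether a benzyl group or a morpholine on the amide-type nitrogen would fall nearer compound 1 or compound 3. A plain phenyl there would show whether the fluorine of the 2-fluorophenyl plays any part.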